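Working notes on an agonist series

The source may hold more compounds than are shown below. What is called first, only, known or untested is meant among the compounds shown, and "the series" means these compounds.

Measured so far:
compound 1 `C/C(=N\NC(=O)c1cc2ccccc2cc1O)c1ccc(N)cc1`: 1100 nM
compound 2 `Cc1cc(C)n(CCOC2CC(=O)Nc3c2c(C)nn3-c2ncnc3nc[nH]c23)n1`: 16 nM

In a functional assay on HEK293 cells for agonist activity at G-protein coupled receptor 39 (Homo sapiens), read by scintillation proximity assay and inositol phosphate accumulation, with a stated time of 75 min, in the presence of a further agent that is not named here (a lower number here means that less compound is needed, a higher number that more compound is needed for the effect), compound 2 gives the lowest of the two numbers; compound 1 stands far higher, beyond the scatter. Compound 3 `Cc1nn(-c2ncnc3nc[nH]c23)c2c1C(OCc1ccc(C#N)cc1)CC(=O)N2` differs from compound 2 by 4-cyanophenyl in place of (3,5-dimethyl-1H-pyrazol-1-yl)methyl on a saturated chain carbon bound to an oxygen on a saturated carbon. Going by the values given here, no measured pair shows this change, so its size is unknown. A modest rise is expected, not clearly beyond the scatter. Compound 3 is expected near 40 nM, within 8 nM to 200 nM. The expected step is a 2.5-fold higher number from compound 2 to compound 3 (0.40 log units; beyond the scatter).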

Compound 3, half-maximal effective concentration: 4 nM
Compound 3: the middle estimate sits 10-fold (1.00 log units) above what was measured; measured number below the stated range.
By their numbers in this assay, from the lowest: compound 3; then compound 2; then compound 1.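

At this place, on a saturated chain carbon bound to an oxygen on a saturated carbon, 4-cyanophenyl in place of (3,5-dimethyl-1H-pyrazol-1-yl)methyl gives a 4.0-fold lower number from compound 2 to compound 3 (0.60 log units; beyond the scatter) in this assay. The five-membered aromatic ring with 2 hetero atoms is therefore not required here: a six-membered aromatic ring of carbon only, with its nitrile, serves at least as well for the same 8 heavy atoms. Nothing at hand explains the step. Going by these compounds, whether the nitrile or the carbon-only ring carries it stays open. So does how a plain benzyl or a longer chain would read at this place.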